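Oxazolidinone amides: from phenoxy to (oxan-4-yl)oxy

The compounds below may be only part of what the source reports. "The series", "measured", "known", "first", "only" and "open" are said of these compounds alone.

Measured so far:
compound 1 `Cc1ccc(CCCCCC(=O)N2CCOC2=O)cc1C`: > 20000 nM
compound 2 `O=C(O)c1cccc(CCCCCC(=O)N2CCOC2=O)c1`: > 20000 nM
compound 3 `O=C1OCCN1C(=O)c1ccc(Oc2ccccc2)cc1`: 680 nM

In an assay on HEK293 cells for inhibition of N-acylethanolamine-hydrolyzing acid amidase (Rattus norvegicus), read by LC-MS, with a stated time of 30 min (a lower number here means a stronger inhibitor, a higher number a weaker inhibitor), compound 1 gives > 20000 nM, which is a limit of the assay and not a number. Compound 2 likewise gives > 20000 nM, again a limit. Compound 1 and compound 2 thus both sit at the limit of > 20000 nM in this assay, at which 2 of the 3 values shown sit. Compound 3 gives 680 nM in this assay, the only number among the three shown, so it is the one point from which any step can be read.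

Compound 4 `O=C1OCCN1C(=O)c1ccc(OC2CCOCC2)cc1` differs from compound 3 in one place: oxan-4-yl in place of phenyl on an oxygen on an aromatic ring. For the measured compounds named here, no measured pair shows this kind of change, so its effect is not anchored by data. The expectation for the step from compound 3 to compound 4 in this assay is a modest weakening, a 2.2-fold higher number from compound 3 to compound 4 (0.34 log units; beyond the scatter), though a result within the scatter would not surprise. Compound 4 is therefore expected to give about 1500 nM, within a range from 400 nM to 6000 nM.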

Compound 4, half-maximal inhibitory concentration: 330 nM
Beside the measured number, compound 4's estimate is 4.5-fold (0.66 log units) above it; the measured number lies below the stated range.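

In this assay, oxan-4-yl in place of phenyl on an oxygen on an aromatic ring gives a 2.1-fold lower number from compound 3 to compound 4 (0.31 log units; beyond the scatter). For the compounds shown here, this is the first step that can be read, and it shows that a group on this oxygen need not be aromatic: a non-aromatic ring of the same heavy-atom count, carrying one hydrogen-bond acceptor, keeps the inhibition and modestly strengthens it. Nothing at hand accounts for the direction of this step.

The compounds shown leave open whether the change in number follows the ring oxygen or the loss of the aromatic ring, a question that cyclohexyl on the same oxygen would address. Also open, from the compounds shown here alone, is how this position responds to an amine or a carboxylic acid on the ring, or to a longer chain in place of the ring.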